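From a Hydroxyphenyl Arm to an Ethyl Ester

The compounds below may be only part of what the source reports. "The series", "measured", "known", "first", "only" and "open" are said of these compounds alone.

Compound 3 `COc1ccc([Se]c2cc(-c3ccc(O)cc3)nc3ccc(OC)cc23)cc1` stands second highest of the three numbers in a functional assay on Jurkat cells (Homo sapiens) for cytotoxicity, read by MTT assay, with a stated time of 24 h; a lower number here means that less compound is needed, a higher number that more compound is needed for the effect: compound 3 gives 41500 nM, compound 1 `CCOC(=O)c1cc([Se]c2ccccc2C)c2cc(OC)ccc2n1` gives 14900 nM, and compound 2 `CCOC(=O)c1cc([Se]c2ccc(F)cc2)c2cc(OC)ccc2n1` gives 134000 nM. Compound 4 `CCOC(=O)c1cc([Se]c2ccc(OC)cc2)c2cc(OC)ccc2n1` differs from compound 3 in one place: ethoxycarbonyl in place of 4-hydroxyphenyl on an aromatic carbon. Going by the values given here, the only measured step, a 9.0-fold higher number from compound 1 to compound 2 (0.95 log units; beyond the scatter), alters the group on selenium rather than the position changed here, so it does not bear on this change directly. Compounds 1 and 2, which both carry the ethoxycarbonyl that enters, show numbers on either side of compound 3. The step of a 1.4-fold higher number from compound 3 to compound 4 (0.16 log units; within the scatter) is therefore expected, toward a higher number, with wide uncertainty. The estimate for compound 4 is 60000 nM, ranging from 15000 nM to 250000 nM.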

Compound 4, half-maximal effective concentration: 82500 nM
Compound 4: the middle estimate sits 1.4-fold (0.14 log units) below what was measured; measured number inside the range.
By their numbers in this assay, from the lowest: compound 1; then compounds 3, 4 and 2 (each within the scatter of the next, the first and the last beyond it).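

In this assay ethoxycarbonyl in place of 4-hydroxyphenyl next to the ring nitrogen gives a 2.0-fold higher number from compound 3 to compound 4 (0.30 log units; within the scatter) and so cannot be told apart from it at this position. Among the ethyl esters, methoxy in place of fluoro gives a 1.6-fold lower number from compound 2 to compound 4 (0.21 log units; within the scatter) and again shows no clear difference, while 4-methoxyphenyl in place of 2-methylphenyl on selenium gives a 5.5-fold higher number from compound 1 to compound 4 (0.74 log units; beyond the scatter) and is a real shift. No measurement here explains these numbers.

Going by these compounds, whether an amine or a carboxylic acid at this position would move the number stays open. So does whether ethoxycarbonyl and 4-hydroxyphenyl would also match with 2-methylphenyl on selenium.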